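Trifluoromethoxy in Place of Trifluoromethyl: An Expected Value

This account rests on a few compounds, and the source may have more. Where it says the series, first, only, none or still open, it means among the compounds named here.

All three measured compounds were tested in an assay on isolated protein for inhibition of 2-Hydroxyacid oxidase 2 (Rattus norvegicus); on this read-out higher numbers stand for weaker inhibition and lower numbers for stronger inhibition:

Compound 1, `Cc1n[nH]c(C(=O)O)c1Cc1cccc(-c2ccc(C#N)cc2)c1`, gives 300 nM.
Compound 2, `Cc1n[nH]c(C(=O)O)c1Cc1cccc(C(N)=O)c1`, gives 900 nM.
Compound 3, `Cc1n[nH]c(C(=O)O)c1Cc1cccc(C(F)(F)F)c1`, gives 300 nM.

Compound 3 stands level with compound 1, the two together giving the lowest numbers of the three, with no change at the digits printed from compound 1 to compound 3 (within the scatter). Against compound 2 the step is a 3.0-fold lower number from compound 2 to compound 3 (0.48 log units; beyond the scatter), a modest gain in this assay.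

Compound 4, `Cc1n[nH]c(C(=O)O)c1Cc1cccc(OC(F)(F)F)c1`, differs from compound 3 in one place: trifluoromethoxy in place of trifluoromethyl on an aromatic carbon. Among the compounds with values here, no measured step swaps these two particular groups, so the expectation rests on what the neighbouring steps show. The step from compound 1 to compound 3 exchanged two quite different groups at this position with no change beyond the scatter, and the largest step seen, a 3.0-fold higher number from compound 1 to compound 2 (0.48 log units; beyond the scatter), was only modest. A change as small as this one is therefore expected to give no change at the digits printed from compound 3 to compound 4 (within the scatter), staying within the scatter. For compound 4 the estimate is 300 nM, with a range from 130 nM to 700 nM.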

Compound 4, half-maximal inhibitory concentration: 700 nM
For compound 4 the middle estimate is 2.3-fold (0.37 log units) below the measured one, within the range that was stated.
By their numbers in this assay, from the lowest: compounds 1 and 3 (each within the scatter of the next); then compounds 4 and 2 (each within the scatter of the next).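

Trifluoromethoxy in place of trifluoromethyl is a small exchange, yet it moves the number in this assay, giving a 2.3-fold higher number from compound 3 to compound 4 (0.37 log units; beyond the scatter), so this position can respond to a slight edit even though the very different 4-cyanophenyl and trifluoromethyl groups gave matching numbers. The comparison with 4-cyanophenyl shows a gap of the same size, a 2.3-fold higher number from compound 1 to compound 4 (0.37 log units; beyond the scatter), whereas the comparison with carbamoyl stays inside the scatter, a 1.3-fold lower number from compound 2 to compound 4 (0.11 log units; within the scatter). Nothing available explains why the added oxygen matters here.

Going by these compounds, it remains open whether methoxy, which lacks the fluorine atoms, would give a number closer to that of trifluoromethyl or of trifluoromethoxy. A single chlorine atom or an amine at this place could also help show how much this position tolerates.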